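This account rests on a few compounds, and the source may have more. Where it says the series, first, only, none or still open, it means among the compounds named here.

Measured compounds:
- compound 1 `COC(=O)c1ccc(OCCCCOc2ccc(C(=O)CC3CCCC3)c(O)c2C)cc1`: "not determined" (no result reported)
- compound 2 `CCC(=O)c1ccc(OCCCCOc2cc(C(=O)O)ccc2OC)c(C)c1O`: 162 nM

Compound 1 `COC(=O)c1ccc(OCCCCOc2ccc(C(=O)CC3CCCC3)c(O)c2C)cc1` has no number against it, so nothing can be said of how it performs. Compound 2 `CCC(=O)c1ccc(OCCCCOc2cc(C(=O)O)ccc2OC)c(C)c1O` is therefore the single reference point: in an assay on HEK293 cells for positive allosteric modulation of metabotropic glutamate receptor 2 (Rattus norvegicus), read by thallium flux, with a stated time of 2.5 min (on this read-out lower numbers stand for an effect already at smaller amounts and higher numbers for an effect only at larger amounts of compound), compound 2 gives 162 nM, the only figure in hand.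

Compound 3 `COc1ccc(C(=O)O)cc1OCCCCOc1ccc(C(=O)CC2CCCC2)c(O)c1C` differs from compound 2 in one place: cyclopentyl in place of methyl on a saturated chain carbon bound to a carbonyl carbon. Going by the values given here, no measured pair shows what this kind of change does in this assay, so any expectation rests on compound 2 alone and on the size of the added group. Among the compounds with values here, with a single anchor and no measured step to lean on, a modest shift is the sensible expectation, and the direction is uncertain; a change on the order of the scatter, or somewhat larger, either way, seems most likely.

Compound 3 is accordingly estimated at 120 nM, within a range of 40 nM to 400 nM, which amounts to an expected step of a 1.4-fold lower number from compound 2 to compound 3 (0.13 log units; within the scatter).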

Compound 3, half-maximal effective concentration: 425 nM
Beside the measured number, compound 3's estimate is 3.5-fold (0.55 log units) below it; the measured number lies above the stated range.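

In this assay, going by these compounds alone, the change of methyl to cyclopentyl on a saturated chain carbon bound to a carbonyl carbon gives a 2.6-fold higher number from compound 2 to compound 3 (0.42 log units; beyond the scatter), the first measured step at this place. It shows that the read-out responds to what sits on this carbon, and that here the larger cyclopentyl group goes with a higher number, meaning an effect only at larger amounts of compound. Compound 3 still returns a number, so the exchange shifts the effect without removing it, and nothing at hand explains the shift.

This is one step between two groups, so it does not show whether the number rises steadily with the size of the group or whether something particular to cyclopentyl is at work; an open chain such as butyl, a smaller ring such as cyclopropyl, or a ring bearing an amine would each speak to that. On these data alone, compound 1 pairs the same cyclopentyl group with a methyl ester but has no number, so whether the step holds on a different background also stays open.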